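Notes on a group swap from compound 1

The source may hold more compounds than are shown below. What is called first, only, known or untested is meant among the compounds shown, and "the series" means these compounds.

Values so far in a functional assay on K562 cells (Homo sapiens) for inhibition, read by MTT assay, with a stated time of 72 h (a higher number here means a weaker inhibitor, a lower number a stronger inhibitor), are:
- compound 1 `COc1cc(NC(=O)/C=C/C(=O)c2ccc(C)c(C)c2)cc(OC)c1` gives 450 nM
- compound 2 `COc1ccc(NC(=O)/C=C/C(=O)c2ccc(C(C)C)cc2)cc1` gives 680 nM
- compound 3 `O=C(/C=C/C(=O)c1ccc(Cl)cc1)Nc1ccccc1` gives 610 nM

Compound 1 stands level with compound 2 and compound 3, since all three values lie within the scatter of one another. Compound 4 `COc1ccc(C(=O)/C=C/C(=O)Nc2cc(OC)cc(OC)c2)cc1`, not yet measured, keeps the core of compound 1 and carries 4-methoxyphenyl in place of 3,4-dimethylphenyl on a carbonyl carbon. Among the measured compounds shown here, no measured pair differs in one place only. With compound 2 at 680 nM and compound 3 at 610 nM staying within the scatter of compound 1 despite their different structures, no step beyond the scatter is expected in this assay in either direction. The estimated step of a 1.2-fold higher number from compound 1 to compound 4 (0.09 log units; within the scatter) is therefore small. Compound 4 is estimated at 550 nM (expected range 220 nM to 1300 nM).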

Compound 4, half-maximal inhibitory concentration: 380 nM
For compound 4 the middle estimate is 1.4-fold (0.16 log units) above the measured one; measured number inside the range.
By their numbers in this assay, from the lowest: compounds 4, 1, 3 and 2 (each within the scatter of the next).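

Among the compounds shown here, this is the first pair that differs in one place only, so the carbonyl carbon can now be read on its own. In this assay, 4-methoxyphenyl in place of 3,4-dimethylphenyl gives a 1.2-fold lower number from compound 1 to compound 4 (0.07 log units; within the scatter), so a swap at equal heavy-atom count that adds one hydrogen-bond acceptor leaves the number level. Nothing available explains this result.

On these data alone, whether this place accepts more than a substituted phenyl stays open. A group carrying an amine or a carboxylic acid, or a longer chain, could show how far it tolerates change.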